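This account rests on a few compounds, and the source may have more. Where it says the series, first, only, none or still open, it means among the compounds named here.

Measured in a functional assay (Saphenous vein) for inhibition, with Oryctolagus cuniculus as the target; on this read-out lower numbers stand for tighter binding and higher numbers for weaker binding:
- Compound 1 `O=C(O)CC/C=C/c1c(Cc2cccnc2)ccc2c1CCC(NS(=O)(=O)c1ccc(Cl)cc1)C2`: 0.00794 nM
- Compound 2 `O=C(O)CCC/C=C/c1c(Cc2cccnc2)ccc2c1CCC(NS(=O)(=O)c1ccc(Cl)cc1)C2`: 1.26 nM

Of these two compounds, compound 2 carries the higher number, at 1.26 nM in this assay, and so the weaker binding. Among the compounds with values here, the only measured step separating the pair is a 160-fold higher number from compound 1 to compound 2 (2.20 log units; beyond the scatter), which is large and beyond the scatter.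

The next compound, compound 3 `O=C(O)CCC/C=C\c1c(Cc2cccnc2)ccc2c1CCC(NS(=O)(=O)c1ccc(Cl)cc1)C2`, keeps the structure of compound 2 except for the geometry of one double bond: the two compounds have the same atoms and bonds; at least one stereo element is drawn with a configuration in one of them and without one in the other: 1 of 2 stereo elements differ; a double bond is drawn E in compound 2 and Z in compound 3.

Within the data shown here, no measured step reverses a double bond, so the size of this change cannot be read directly from the data. Among the measured compounds shown here, the one available step, a 160-fold higher number from compound 1 to compound 2 (2.20 log units; beyond the scatter), is a different change, but it shows that the number can shift strongly within this small series. A step beyond the scatter is therefore plausible, though far from certain, and a modest move towards weaker binding is a cautious expectation. The expected change is a 2.4-fold higher number from compound 2 to compound 3 (0.38 log units; beyond the scatter). For compound 3 the estimated value is 3 nM, with an expected range from 0.3 nM to 30 nM.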

Compound 3, dissociation constant: 0.2 nM
Estimate against measurement, compound 3: 15-fold (1.18 log units) above; the measured number lies below the stated range.
By their numbers in this assay, from the lowest: compound 1; then compound 3; then compound 2.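

In this assay, the geometry of the double bond proves to matter in its own right on the 5-carboxypent-1-en-1-yl chain: with atoms and bonds unchanged, the step is a 6.3-fold lower number from compound 2 to compound 3 (0.80 log units; beyond the scatter), so the Z form gives the tighter binding of the pair. The Z form closes only part of the gap to the shorter chain, with a 25-fold higher number from compound 1 to compound 3 (1.40 log units; beyond the scatter), and compound 3 therefore takes the middle place in the series, although this step joins two chains that also differ in how their double bonds are drawn. One reservation applies to how the geometry step is read: the fact that one of compounds 2 and 3 is drawn with a defined configuration and the other without, at the place where they differ.

On these data alone, whether the Z form would also give tighter binding on the shorter 4-carboxybut-1-en-1-yl chain remains open, so the contributions of chain length and double-bond geometry cannot yet be fully separated. As far as these compounds go, how a longer chain such as 6-carboxyhex-1-en-1-yl, a fully saturated chain, or an amide or tetrazole in place of the carboxylic acid would read in this assay also remains open.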